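A few compounds are considered here, and "the series" means these few. Any claim that something is new, unique, unknown or untested is made for them only; others in the source may bear on it.

Measured so far:
`COc1cccc([C@@H](CO)O[C@H]2CCCN(Cc3ccc(C(=O)O)cc3C)[C@H]2c2ccccc2)c1` — compound 1, 81000 nM
`Cc1cc(C(=O)O)ccc1CN1CCC[C@H](O[C@H](CO)c2cc(Cl)cc(Cl)c2)[C@@H]1c1cccc(F)c1` — compound 2, 12000 nM

In an assay on isolated protein for activation of cGMP-dependent protein kinase 1 (Homo sapiens), read by ADP-Glo, with stated times of 30 min and 2 h, in the presence of a further agent that is not named here (on this read-out higher numbers stand for an effect only at larger amounts of compound and lower numbers for an effect already at smaller amounts), compound 1 stands at the highest number of the two; compound 2 gives a lower number, and that gap lies beyond the scatter. Compound 3 `Cc1cc(C(=O)O)ccc1CN1CCC[C@H](O[C@H](CO)c2cccc(Cl)c2)[C@@H]1c1ccccc1` is not yet measured. It differs from compound 1 in one place: chloro in place of methoxy on an aromatic carbon. For the measured compounds named here, no measured pair shows this change alone. A step of moderate size toward a lower number is expected from compound 1 to compound 3, a 2.3-fold lower number from compound 1 to compound 3 (0.36 log units; beyond the scatter), since compound 2, which also carries chloro groups, gives 12000 nM. Compound 3 is thus estimated at 35000 nM, within 12000 nM to 90000 nM.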

Compound 3, half-maximal effective concentration: 1300 nM
The estimate for compound 3 lay 27-fold (1.43 log units) above the measured number; the measured number lies below the stated range.
By their numbers in this assay, from the lowest: compound 3; then compound 2; then compound 1.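

In this assay, for the compounds shown here, the single change from 3-methoxyphenyl to 3-chlorophenyl gives a 62-fold lower number from compound 1 to compound 3 (1.79 log units; beyond the scatter) with the rest of the structure unchanged. This aromatic position therefore has a large bearing on the read-out, which the earlier pair, differing in more than one place, could not show. Nothing at hand accounts for the size of this step.

Still open, on these data alone, is whether the step follows from the arrival of chloro or the departure of methoxy. Bromo, nitrile or a bare hydrogen on this carbon would help separate the two.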